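Adding a methoxy group to the aryl ether of compound 2

The source may report more compounds than this note shows. Statements on the series, on what has been measured and on what is new or still open speak of the compounds shown alone.

Measured compounds:
- compound 1 `C=C(C)[C@@H]1CC=C(Cn2cc(COc3cc(C4NC(=O)NC(C)=C4C(C)=O)ccc3OC)nn2)CC1`: > 100000 nM
- compound 2 `C=C(C)[C@@H]1CC=C(Cn2cc(COc3cccc(C4NC(=O)NC5=C4C(=O)CC(C)(C)C5)c3)nn2)CC1`: 21900 nM

Of the compounds shown here, two have been tested in a functional assay on PC-3 cells (Homo sapiens) for inhibition, read by sulforhodamine B assay, with a stated time of 48 h; on this read-out higher numbers stand for weaker inhibition of growth and lower numbers for stronger inhibition of growth. Compound 1 reached only the limit of the assay, > 100000 nM, which is a boundary rather than a number. In this assay, within the data shown here, compound 2 gives 21900 nM, the only actual number among the two results. The result of compound 1 is a limit (the limit of > 100000 nM in this assay, at which 1 of the 2 values shown sits).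

Compound 3 `C=C(C)[C@@H]1CC=C(Cn2cc(COc3cc(C4NC(=O)NC5=C4C(=O)CC(C)(C)C5)ccc3OC)nn2)CC1` has not yet been measured. It differs from compound 2 in one place: methoxy in place of hydrogen on an aromatic carbon. Among the measured compounds shown here, no pair of measured compounds differs by exactly this change, so the size of the step can only be anticipated. Compound 1 also carries a methoxy group on its aryl ether, but it has a different core as well, so its limit value cannot be read as the effect of the methoxy group alone.

The step from compound 2 to compound 3 is expected to be a 2.1-fold higher number from compound 2 to compound 3 (0.31 log units; beyond the scatter), toward weaker inhibition of growth. Compound 3 is therefore estimated to give 45000 nM in this assay, within a range from 15000 nM to 120000 nM.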

Compound 3, concentration for total growth inhibition: 79900 nM
Beside the measured number, compound 3's estimate is 1.8-fold (0.25 log units) below it; the measured number falls inside the stated range.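

In this assay, putting a methoxy group in place of hydrogen on this aromatic carbon, ortho to a large group and para to a large group, gives a 3.6-fold higher number from compound 2 to compound 3 (0.56 log units; beyond the scatter). Among these compounds, this is the first step in which this change stands alone, with the shared core and the rest of the molecule unchanged, and both of its ends are real numbers. It shows that this place on the ring is not indifferent to substitution: here, methoxy moves the result toward weaker inhibition of growth, though the step is modest and compound 3 still gives a measurable value. Compound 1 also carries the methoxy group, but its result is a limit and not a number: the limit of > 100000 nM in this assay, at which 1 of the 3 values shown sits.

On these data alone, what stays open is whether this loss belongs to methoxy in particular or would come with other groups on the same carbon, such as a hydroxyl group, a chlorine atom or a longer ethoxy chain. As far as these compounds go, it is also open whether the same change would have a similar effect on the core of compound 1, where no step can be read.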